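The source may hold more compounds than are shown below. What is called first, only, known or untested is meant among the compounds shown, and "the series" means these compounds.

Two amides built on the same bicyclic core have been measured. Compound 1 `CCCCCCCCCCC1(C(=O)Nc2c(C)cc(C)c3c2OC(C)(C)C3)CCCC1` carries a decyl chain and a cyclopentane at the carbon next to the carbonyl, and in an assay for inhibition of acyl-CoA:cholesterol acyltransferase (Oryctolagus cuniculus), using microsomes (on this read-out lower numbers stand for stronger inhibition and higher numbers for weaker inhibition), compound 1 gives 170 nM. Compound 2 `CCCCCCCCC(C)(C)C(=O)Nc1c(C)cc(C)c2c1OC(C)(C)C2` instead carries an octyl chain and two methyl groups at that carbon, and in this assay compound 2 gives 140 nM. Of the two numbers, that of compound 2 is the lower one, but the gap to compound 1 lies within the usual scatter, so the two are best read as indistinguishable.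

Compound 3 `Cc1cc(C)c(NC(=O)C(C)(C)CCCOc2ccc(Cl)cc2)c2c1CC(C)(C)O2` is the next step. It differs from compound 2 by 4-chlorophenoxy in place of pentyl on a saturated chain carbon, four bonds along the chain from a carbonyl carbon. For the measured compounds named here, no measured pair shows what such a change does on this core, so the expectation rests only on the two numbers given. The step in this assay is expected to be small and is estimated as a 1.4-fold lower number from compound 2 to compound 3 (0.15 log units; within the scatter), most likely toward a somewhat lower number, but possibly within the scatter. Compound 3 is therefore estimated at 100 nM, with a range from 30 nM to 400 nM.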

Compound 3, half-maximal inhibitory concentration: 260 nM
Compound 3: middle estimate off by 2.6-fold (0.41 log units), on the low side; measured number inside the range.
By their numbers in this assay, from the lowest: compounds 2, 1 and 3 (each within the scatter of the next).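

In this assay the change reads as a 1.9-fold higher number from compound 2 to compound 3 (0.27 log units; within the scatter) and so gives the first view of this position, on a saturated chain carbon, four bonds along the chain from a carbonyl carbon. Until now only plain carbon chains had been seen on the shared core, and here 4-chlorophenoxy, with its six-membered aromatic ring, its oxygen and its chlorine, takes the place of pentyl without a difference that can be told from repeat measurement. Nothing available explains the step or assigns any share of it to the ring, the oxygen or the chlorine.

Going by these compounds, what stays open is which part of the entering group, if any, matters: plain phenoxy, 4-fluorophenoxy or 4-chlorobenzyl at the same place would separate the chlorine and the oxygen from the ring. Also open, on these data alone, is whether a charged end to the chain, such as an amine or a carboxylic acid, or a longer chain carrying the same 4-chlorophenoxy, would stay within the scatter of compound 2 on this core.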